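The source may report more compounds than this note shows. Statements on the series, on what has been measured and on what is new or still open speak of the compounds shown alone.

In a physicochemical assay for lipophilicity, read by HPLC, in phosphate buffer, measured as octanol-water partition, with a stated time of 1 h, at pH 7.4 (on this read-out higher numbers stand for higher lipophilicity and lower numbers for lower lipophilicity), compound 1 (`N#Cc1ccc(C(=O)Nc2ccc(F)c([C@]3(C4CC4)C=C(CF)OC(N)=N3)c2)nc1`) gives 2.9 and compound 2 (`COCC1=C[C@@](C)(c2cc(NC(=O)c3ccc(C#N)cn3)ccc2F)N=C(N)O1`) gives 2 while compound 3 (`C[C@@]1(c2cc(NC(=O)c3cnc(C(F)F)cn3)ccc2F)C=C(CF)OC(N)=N1`) gives 2.5 and so stands second highest of the three, with both gaps beyond the scatter. Compound 4 (`C[C@@]1(c2cc(NC(=O)c3coc(CF)n3)ccc2F)C=C(CF)OC(N)=N1`) departs from compound 3 in one place (2-(fluoromethyl)-1,3-oxazol-4-yl in place of 5-(difluoromethyl)pyrazin-2-yl on a carbonyl carbon), where 2-(fluoromethyl)-1,3-oxazol-4-yl stands in place of 5-(difluoromethyl)pyrazin-2-yl on a carbonyl carbon. Among the measured compounds shown here, no measured pair shows this change directly, so the expectation remains a judgement from the structures and the spread of the three values. A moderate fall in this assay is expected (a number 0.40 log units lower from compound 3 to compound 4 (beyond the scatter)), somewhat beyond the scatter. Compound 4 is expected at 2.1 (estimated range 1.6 to 2.6).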

Compound 4, distribution coefficient: 2.2
For compound 4 the middle estimate is 0.10 log units below the measured one; the measured number falls inside the stated range.
By their numbers in this assay, from the lowest: compounds 2, 4 and 3 (each within the scatter of the next, the first and the last beyond it); then compound 1.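

In this assay, among the compounds shown here, the earlier compounds offered no pair differing in one place, and now 2-(fluoromethyl)-1,3-oxazol-4-yl in place of 5-(difluoromethyl)pyrazin-2-yl gives a number 0.30 log units lower from compound 3 to compound 4 (within the scatter) on a carbonyl carbon. At this position, then, a five-membered aromatic ring can stand for a six-membered one without a step beyond the scatter. Nothing shown gives a cause for this step. The ring and its fluorinated group change together here, and the compounds shown do not separate the two. On these data alone, what a carboxylic acid or an amine in this place would give in this assay also stays open.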